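Phenyl added to the saturated ring of compound 1

The compounds below may be only part of what the source reports. "The series", "measured", "known", "first", "only" and "open" are said of these compounds alone.

Compound 1 `O=C(CCc1ccc(Cl)cc1)C(=O)N1CCCCC1` is the parent of this small series. In an assay on HEK-293T cells for inhibition of phospholipase A and acyltransferase 4 (Homo sapiens), with stated times of 30 min and 20 min (a higher number here means a weaker inhibitor, a lower number a stronger inhibitor), compound 1 gives > 10000 nM, which is a limit of the assay and not a number. Compound 2 `O=C(CCc1ccc(Cl)cc1)C(=O)N1CCOCC1` carries morpholin-4-yl in place of piperidin-1-yl on the carbonyl carbon; in this assay compound 2 gives > 10000 nM, again a limit. Compound 3 `O=C(CCc1ccc(Cl)cc1)C(=O)N1CCCC1` carries pyrrolidin-1-yl on the carbonyl carbon; in this assay compound 3 gives > 10000 nM, also a limit. The steps a step that the two limits leave unreadable from compound 1 to compound 2, a step that the two limits leave unreadable from compound 1 to compound 3 and a step that the two limits leave unreadable from compound 2 to compound 3 cannot be sized, because of the limit of > 10000 nM in this assay, at which 3 of the 3 values shown sit. Among the compounds with values here, compound 1 therefore stands at the limit together with its two companions, and no measured step in this assay separates the three rings.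

Compound 4 `O=C(CCc1ccc(Cl)cc1)C(=O)N1CCCC[C@H]1c1ccccc1` differs from compound 1 by phenyl in place of hydrogen on a saturated ring carbon. Within the data shown here, none of the measured steps alters a saturated ring carbon; each exchanges the whole ring on the carbonyl carbon, and all are unreadable, so none gives a direction for this assay. The phenyl is a sizeable addition to a series without measurable inhibition so far, and the expectation is correspondingly open. Compound 4 is estimated at 5000 nM in this assay, with a range of 500 nM to 20000 nM. The expected step is an at least 2.0-fold lower number from compound 1 to compound 4 (0.30 log units; that floor lies within the scatter), with a real chance that only a limit is reported again.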

Compound 4, half-maximal inhibitory concentration: > 10000 nM
Compound 4 gave a limit, no number; the forecaster's own chance of this, stated with the estimate: 50%; middle value at least 2.0-fold (0.30 log units) from the limit.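

In this assay compound 4 gives > 10000 nM, a limit of the assay and not a number. The step from compound 1 to compound 4 therefore cannot be read, because both compounds sit at the same limit: the limit of > 10000 nM in this assay, at which 4 of the 4 values shown sit. The compounds shown leave open which change to the core of compound 1, if any, would give a measurable value in this assay.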